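The compounds below may be only part of what the source reports. "The series", "measured", "known", "first", "only" and "open" are said of these compounds alone.

In an ADME assay on L929 cells (Mus musculus) for cytotoxicity, read by resazurin assay, with a stated time of 72 h (on this read-out higher numbers stand for weaker inhibition and lower numbers for stronger inhibition), compound 1 (`O=C(/C=C/c1ccc2c(c1)B(O)OC2)c1ccccc1`) gives > 10 ug/mL, which is a limit and not a number. Compound 4 (`O=C(/C=C/c1ccc2c(c1)B(O)OC2)c1ccc(I)cc1`) differs from it by iodo in place of hydrogen on an aromatic carbon. Two measured compounds each differ from compound 1 in one place: compound 2 (`COc1ccccc1C(=O)/C=C/c1ccc2c(c1)B(O)OC2`), with methoxy, gives 6.35 ug/mL, and compound 3 (`COCOc1ccccc1C(=O)/C=C/c1ccc2c(c1)B(O)OC2`), with methoxymethoxy, gives 9.02 ug/mL. The measured steps are an at least 1.5-fold lower number from compound 1 to compound 2 (0.19 log units; that floor lies within the scatter) and an at least 1.1-fold lower number from compound 1 to compound 3 (0.04 log units; that floor lies within the scatter), and both floors lie within the scatter. No step beyond the scatter is therefore expected, and the estimated change is an at least 1.2-fold lower number from compound 1 to compound 4 (0.09 log units; that floor lies within the scatter). Compound 4 is expected at 8 ug/mL, with an estimated range from 3.5 ug/mL to 18 ug/mL.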

Compound 4, half-maximal inhibitory concentration: > 10 ug/mL
Compound 4: only a limit was reported; the forecaster's own chance of this, stated with the estimate: 35%; at least 1.2-fold (0.09 log units) between middle value and limit.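

Compound 1 and compound 4 both stand as limits and not as numbers, so no step between them can be read: the limit of > 10 ug/mL in this assay, at which 2 of the 4 values shown sit.

What the compounds shown leave open is whether iodo in place of hydrogen on an aromatic carbon moves the number in this assay at all, and in which direction.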